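This account rests on a few compounds, and the source may have more. Where it says the series, first, only, none or still open, it means among the compounds named here.

Three sulfonyl piperazine ureas and thioureas from one series were examined in an assay for binding affinity to Apoptosis regulator Bcl-2 (Homo sapiens), read by fluorescence polarization, with stated times of 30 min and 20 min, tested at 100 uM; on this read-out higher numbers stand for more inhibition at the one concentration tested (going by the name of the read-out) and lower numbers for less inhibition. Compound 1 `COc1ccc(Oc2ccccc2-c2ccsc2S(=O)(=O)N2CCN(C(=O)Nc3ccc([N+](=O)[O-])cc3)CC2)cc1OC` gives 17% in this assay. Compound 2 `O=C(Nc1cccc([N+](=O)[O-])c1)N1CCN(S(=O)(=O)c2sccc2-c2ccccc2Oc2ccc(O)c(O)c2)CC1` gives 30%, and compound 3 `COc1ccc(Oc2ccccc2-c2ccsc2S(=O)(=O)N2CCN(C(=S)Nc3cc(C(F)(F)F)cc(C(F)(F)F)c3)CC2)cc1OC` gives 25%. Among these three numbers compound 1 stands lowest: its gap to compound 3 lies within the scatter of repeated measurements, so no order between those two can be claimed, whereas its gap to compound 2 lies beyond the scatter.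

The unmeasured compound 4 `COc1ccc(Oc2ccc([N+](=O)[O-])cc2-c2ccsc2S(=O)(=O)N2CCN(C(=O)Nc3ccc([N+](=O)[O-])cc3)CC2)cc1OC` differs from compound 1 in one place: nitro in place of hydrogen on an aromatic carbon. Among the measured compounds shown here, no pair of measured compounds here differs by a single change of this kind, so the data give no measured step from which to read its effect.

The estimate for compound 4 therefore rests on compound 1 alone, and the step of a number 3 percentage points higher from compound 1 to compound 4 (within the scatter) is expected to be none beyond the scatter. Compound 4 is expected to give about 20% in this assay, within a range from 5% to 40%.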

Compound 4, a percentage reported as inhibition, at one concentration (the size of the read-out at that concentration, not a potency): 19%
Compound 4: middle estimate off by 1 percentage points, on the high side; low and high end bracket the measured number.
By their numbers in this assay, from the lowest: compounds 1, 4, 3 and 2 (each within the scatter of the next, the first and the last beyond it).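

In this assay, among the compounds shown here, nitro in place of hydrogen on an aromatic carbon, para to a 3,4-dimethoxyphenoxy group, gives the first single change that can be read: a number 2 percentage points higher from compound 1 to compound 4 (within the scatter). For the compounds shown here, at this position, then, a nitro group with its 3 heavy atoms and no net charge leaves the read-out at the one concentration tested without a step beyond the scatter, which the earlier compounds, none differing in one place, could not show. No measurement accompanies this result that could explain it.

On these data alone, whether an amine or a carboxylic acid at the same position would also stay within the scatter remains open. So does whether nitro at this position would give a similar step on compound 2 or compound 3.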